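Methoxy Added to the Phenyl Ring of Compound 1

The source may hold more compounds than are shown below. What is called first, only, known or untested is meant among the compounds shown, and "the series" means these compounds.

compound 1, `COc1cccc2cc(C(=O)Nc3c(C#N)ncn3-c3ccccc3)c(=N)oc12`: 40%
compound 2, `COc1cccc2cc(C(=O)NCC(O)CO)c(=O)oc12`: 1%

In an assay on HeLa cells for displacement of a labelled ligand from adenosine receptor A3 (Homo sapiens), read by scintillation counting, with a stated time of 180 min, tested at 10 uM (on this read-out higher numbers stand for more inhibition at the one concentration tested (going by the name of the read-out) and lower numbers for less inhibition), compound 1 gives 40%, the highest of the two numbers measured. Compound 2 gives 1% in this assay, a number lower by a margin beyond the scatter. Going by the values given here, compound 2 differs from compound 1 in more than one place, so the two values show only that compound 1 stands higher; no single change can be read from them.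

Compound 3 `COc1ccc(-n2cnc(C#N)c2NC(=O)c2cc3cccc(OC)c3oc2=N)cc1` has not yet been measured in this assay. It differs from compound 1 by methoxy in place of hydrogen on an aromatic carbon. Among the compounds with values here, no step between measured compounds bears on this change, so no direction can be drawn from the data, and the expected step of no change at the digits printed from compound 1 to compound 3 (within the scatter) is none beyond the scatter. Compound 3 is expected to give about 40% in this assay, with an estimated range from 15% to 65%.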

Compound 3, a percentage reported as inhibition, at one concentration (the size of the read-out at that concentration, not a potency): 42%
Beside the measured number, compound 3's estimate is 2 percentage points below it; low and high end bracket the measured number.
By their numbers in this assay, from the lowest: compound 2; then compounds 1 and 3 (each within the scatter of the next).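

In this assay, going by these compounds alone, going from phenyl to 4-methoxyphenyl gives a number 2 percentage points higher from compound 1 to compound 3 (within the scatter) and provides the first reading of a change in one place, which the earlier pair, differing in more than one place, could not give. At the one concentration tested, the methoxy group, para to a large group, therefore leaves the inhibition reading within the scatter of that of compound 1. Nothing at hand accounts for this result.

From the compounds shown here alone, whether this position would give a similar reading with an amine, a carboxylic acid or a longer alkoxy chain remains open. Going by these compounds, it is also open whether methoxy on another carbon of this ring would read the same, and whether the result would hold at other concentrations.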